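Methyl ester to free acid at the assay limit

This account rests on a few compounds, and the source may have more. Where it says the series, first, only, none or still open, it means among the compounds named here.

Compound 1 `O=C(O)CCCCCCC(=O)Nc1ccc(C2=C(c3ccc(O)cc3)C3CC(S(=O)(=O)Oc4cccc5ccccc45)C2O3)cc1` and compound 2 `COC(=O)CCCCCCC(=O)Nc1cccc(OS(=O)(=O)C2CC3OC2C(c2ccc(O)cc2)=C3c2ccc(O)cc2)c1` were both read in an ADME assay on Vero cells (Chlorocebus sabaeus) for inhibition, read by MTT assay, with a stated time of 72 h; on this read-out lower numbers stand for stronger inhibition and higher numbers for weaker inhibition. Compound 1 gives > 100000 nM, a limit and not a number. Compound 2 gives > 100000 nM, likewise a limit. Compound 2 therefore stands at the limit of > 100000 nM in this assay, at which 2 of the 2 values shown sit. Compound 3 `O=C(O)CCCCCCC(=O)Nc1cccc(OS(=O)(=O)C2CC3OC2C(c2ccc(O)cc2)=C3c2ccc(O)cc2)c1` follows from compound 2 by hydrogen in place of methyl on an oxygen next to a carbonyl group, methoxycarbonyl to carboxy. For the measured compounds named here, no measured pair shows this change. In this assay, a number no higher from compound 2 to compound 3 (the limit leaves the size open) is expected to stay within the scatter, in neither direction. For compound 3 the estimated value is 100000 nM, with an expected range of 50000 nM to 200000 nM.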

Compound 3, half-maximal inhibitory concentration: > 100000 nM
Compound 3 was reported as a limit (the forecaster's own chance of this, stated with the estimate: 85%); the middle value sits exactly at the limit.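

Compound 2 and compound 3 are both reported as limits, so no step can be read for methoxycarbonyl to carboxy. The compounds shown leave open whether any change to this series gives a measurable number in this assay: the limit of > 100000 nM in this assay, at which 3 of the 3 values shown sit.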